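Thiophen-2-yl in place of pyridin-2-yl on compound 3

The compounds below may be only part of what the source reports. "The series", "measured", "known", "first", "only" and "open" are said of these compounds alone.

In a physicochemical assay, with a stated time of 10 min (a higher number here means a weaker inhibitor, a lower number a stronger inhibitor), compound 1 (`C/C(=N\N=C1/SCC(=O)N1Cc1cccc(F)c1)c1cccs1`) gives 4640000 nM and compound 2 (`C/C(=N\N=C1/SCC(=O)N1Cc1cccc(Cl)c1)c1cccs1`) gives 1640000 nM. Compound 3 (`C/C(=N/N=C1\SCC(=O)N1Cc1ccc(F)cc1)c1ccccn1`) gives 3670000 nM, which is within the scatter of compound 1 and higher than compound 2, beyond the scatter. Compound 4 (`C/C(=N/N=C1\SCC(=O)N1Cc1ccc(F)cc1)c1cccs1`) has thiophen-2-yl in place of pyridin-2-yl on a carbon with a double bond to nitrogen. For the measured compounds named here, the only measured step, a 2.8-fold lower number from compound 1 to compound 2 (0.45 log units; beyond the scatter), is modest and concerns chloro in place of fluoro on an aromatic carbon, so no measured step shows this swap. Compound 1 also carries thiophen-2-yl, and its 4640000 nM is within the scatter of compound 3. No step beyond the scatter is therefore expected in this assay. The estimated step is a 1.1-fold higher number from compound 3 to compound 4 (0.04 log units; within the scatter). For compound 4 the estimate is 4000000 nM, with an expected range of 1800000 nM to 8000000 nM.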

Compound 4, half-maximal inhibitory concentration: 3900000 nM
Beside the measured number, compound 4's estimate is 1.0-fold (0.01 log units) above it, within the range that was stated.
By their numbers in this assay, from the lowest: compound 2; then compounds 3, 4 and 1 (each within the scatter of the next).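

For the compounds shown here, the step of a 1.1-fold higher number from compound 3 to compound 4 (0.03 log units; within the scatter) in this assay is the first direct reading at this position, on the carbon with a double bond to nitrogen. It shows that, with the rest of the molecule held the same, a five-membered thiophen-2-yl ring and a six-membered pyridin-2-yl ring give numbers within the scatter of each other. No available evidence explains this match. Both groups are aromatic rings, so the compounds shown leave open how a non-aromatic group, such as an amine or a carboxylic acid, would behave here.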